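Ethyl on the Anilino Nitrogen of a Complement C1r Inhibitor

This account rests on a few compounds, and the source may have more. Where it says the series, first, only, none or still open, it means among the compounds named here.

Measured compounds:
compound 1 `O=c1oc(Nc2ccccc2I)nc2ccccc12` — 3500 nM
compound 2 `O=c1oc(Nc2cccc(I)c2)nc2ccccc12` — > 62500 nM

Of the compounds shown here, two have been measured in an assay on isolated protein for inhibition of complement C1r subcomponent (Homo sapiens); a higher number here means a weaker inhibitor, a lower number a stronger inhibitor. Among the compounds with values here, compound 1 `O=c1oc(Nc2ccccc2I)nc2ccccc12` gives 3500 nM and holds the only numeric value in the set. Compound 2 `O=c1oc(Nc2cccc(I)c2)nc2ccccc12` is reported only as > 62500 nM, which is a limit of this assay and not a number (the limit of > 62500 nM in this assay, at which 1 of the 2 values shown sits). Within the data shown here, since no two measured compounds differ in a single place, there is no measured step against which a new change can be sized.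

Compound 3 `CCN(c1nc2ccccc2c(=O)o1)c1ccccc1I` differs from compound 1 by ethyl in place of hydrogen on a nitrogen on an aromatic ring. Nothing in the measured pair speaks to this particular change, so the expectation rests on the change itself: the hydrogen on the nitrogen leaves and an ethyl of two carbons enters in its place. The step is expected to go toward weaker inhibition and to lie beyond the scatter, a 3.4-fold higher number from compound 1 to compound 3 (0.54 log units; beyond the scatter). Compound 3 is therefore estimated at 12000 nM, with a range from 2500 nM to 62500 nM, and a fair chance that only a limit is reported.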

Compound 3, half-maximal inhibitory concentration: > 62500 nM
Compound 3: a limit, no number; the forecaster's own chance of this, stated with the estimate: 35%; middle value at least 5.2-fold (0.71 log units) from the limit.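

In this assay compound 3 is reported as > 62500 nM, which is a limit of the assay and not a number. Within the data shown here, this gives the first measured step at this place, ethyl in place of hydrogen on a nitrogen on an aromatic ring, and it is a large move toward weaker inhibition, an at least 17-fold higher number from compound 1 to compound 3 (1.25 log units; beyond the scatter), so the hydrogen on that nitrogen cannot be exchanged for ethyl while keeping the inhibition of compound 1, and how far the loss extends stays unknown. Compound 1 remains the only compound in the set with a numeric value, and the other two compounds both stand at one limit: the limit of > 62500 nM in this assay, at which 2 of the 3 values shown sit.

The compounds shown leave open whether a methyl on that nitrogen, or an acetyl or a longer chain, would still give a number in this assay rather than a limit. They also cannot separate what the departing hydrogen contributes to this step from what the entering ethyl contributes, and a methyl on that nitrogen would be the closest next comparison with compound 1.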